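The source may report more compounds than this note shows. Statements on the series, on what has been measured and on what is new or still open speak of the compounds shown alone.

Compound 1, `COc1cc2c(Oc3ccc(NC(=O)c4nn(-c5cccc(F)c5)c(=O)c5ccccc45)cc3F)ccnc2cc1OCCCN1CCCC1`, gives 190 nM in a functional assay on NCI-H460 cells (Homo sapiens) for cytotoxicity, read by MTT assay, with a stated time of 72 h; on this read-out higher numbers stand for weaker inhibition and lower numbers for stronger inhibition.
Compound 2, `COc1cc2c(Oc3ccc(NC(=O)c4nn(-c5ccc(Br)cc5)c(=O)c5ccccc45)cc3F)ccnc2cc1OCCCN1CCCC1`, gives 180 nM.
Compound 3, `COc1cc2c(Oc3ccc(NC(=O)c4nn(-c5ccc(F)cc5)c(=O)c5ccccc45)cc3F)ccnc2cc1OCCCN1CCN(C)CC1`, gives 91 nM.

Among these three, compound 3 gives the lowest number. Its gap to compound 2 lies within the usual scatter of repeated measurements, so those two cannot be ranked against each other, while its gap to compound 1 lies just beyond that scatter.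

Compound 4, `COc1cc2c(Oc3ccc(NC(=O)c4nn(-c5ccc([N+](=O)[O-])cc5)c(=O)c5ccccc45)cc3F)ccnc2cc1OCCCN1CCN(C)CC1`, has not yet been measured. It differs from compound 3 in one place: nitro in place of fluoro on an aromatic carbon. Within the data shown here, the only measured step that touches the same region, the aryl group on the aromatic nitrogen, is a 1.1-fold lower number from compound 1 to compound 2 (0.02 log units; within the scatter), where swapping one halogenated phenyl for another left the number essentially unchanged. That step does not involve a nitro group, so it bears only loosely on the present change, and nothing else among the measured compounds addresses a nitro group at all. Among the measured compounds shown here, with the one relevant comparison showing no movement, the expected step in this assay is a 1.1-fold higher number from compound 3 to compound 4 (0.04 log units; within the scatter), that is, no change beyond the scatter. Compound 4 is therefore estimated at 100 nM, with a likely range from 40 nM to 250 nM.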

Compound 4, half-maximal inhibitory concentration: 980 nM
For compound 4 the middle estimate is 9.8-fold (0.99 log units) below the measured one, and the stated range ends below it.
By their numbers in this assay, from the lowest: compounds 3, 2 and 1 (each within the scatter of the next, the first and the last beyond it); then compound 4.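

In this assay, going from 4-fluorophenyl to 4-nitrophenyl gives an 11-fold higher number from compound 3 to compound 4 (1.03 log units; beyond the scatter), so the group carried on this aromatic carbon, para to a large group, can change the number strongly. Among these compounds, the only earlier step on this aryl group, a 1.1-fold lower number from compound 1 to compound 2 (0.02 log units; within the scatter), exchanged one halogen for another and stayed within the scatter, so it suggested a tolerant region; the nitro result shows that this tolerance does not extend to every replacement, at least in compound 4, which carries a group of three heavy atoms with two hydrogen-bond acceptors where compound 3 has a single fluorine. No measurement shown here says what lies behind this large step.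

The compounds shown leave open whether the weaker result belongs to nitro itself or would appear with other groups at this place, such as an amine, a nitrile or a methoxy group, any of which would help to separate those possibilities. From the compounds shown here alone, it also remains open whether a 4-nitrophenyl group would give a similar step when paired with the side chain of compound 2.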